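This account rests on a few compounds, and the source may have more. Where it says the series, first, only, none or still open, it means among the compounds named here.

Three compounds on the shared core have numbers in a functional assay on HUVEC cells (Homo sapiens) for inhibition, with a stated time of 4 days; a higher number here means a weaker inhibitor, a lower number a stronger inhibitor. Compound 1 `COc1ccc(C(N)=O)cc1COc1ccc(Cl)c(C)c1` gives 640 nM, compound 2 `COc1ccc(C(N)=O)cc1/C=C/c1ccc(Cl)cc1` gives 87 nM and compound 3 `COc1ccc(C(N)=O)cc1/C=C\c1ccc(Cl)cc1` gives 2900 nM, so compound 2 holds the lowest number of the three, and both others lie beyond the scatter from it.

Compound 4 `COc1ccc(C(N)=O)cc1/C=C/c1ccccc1` is not yet measured. Its change from compound 2 is hydrogen in place of chloro on an aromatic carbon, para to a large group.

Among the measured compounds shown here, the only measured step between closely matched compounds is a 33-fold higher number from compound 2 to compound 3 (1.52 log units; beyond the scatter). This large step goes with the fact that compounds 2 and 3 differ only in the configuration as drawn, and the chloro stays in place across it. It therefore shows how far numbers can move in this series but gives no size for losing the chloro. For the measured compounds named here, no measured pair isolates that change.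

The expectation is a moderate move towards a weaker number in this assay, with a wide margin in either direction, as compound 2 at 87 nM already sits at the low end of the series. The expected change is a 2.9-fold higher number from compound 2 to compound 4 (0.46 log units; beyond the scatter). For compound 4 the estimated value is 250 nM, with an expected range from 70 nM to 900 nM.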

Compound 4, half-maximal inhibitory concentration: 2400 nM
Compound 4: middle estimate off by 9.6-fold (0.98 log units), on the low side; measured number above the stated range.
By their numbers in this assay, from the lowest: compound 2; then compound 1; then compounds 4 and 3 (each within the scatter of the next).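

In this assay the chloro on the aromatic carbon, para to a large group, turns out to matter a great deal: hydrogen in its place gives a 28-fold higher number from compound 2 to compound 4 (1.44 log units; beyond the scatter), a large step from the loss of one heavy atom, with the E double bond kept. Among the compounds shown here, until now the only large step was a 33-fold higher number from compound 2 to compound 3 (1.52 log units; beyond the scatter), which came from the configuration of the double bond with the chloro in place, so the series now has a second, separate change at which the low number of compound 2 is lost. Nothing shown here gives a reason for the size of the step on losing the chloro.

The compounds shown leave open whether a fluoro, a methyl or a methoxy group at this place would hold the number near that of compound 2 or move it towards that of compound 4, and so whether the step belongs to chlorine itself or to any group there. Also open, on these data alone, is whether the same exchange of chloro for hydrogen would move the number by a similar size with the Z double bond of compound 3.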